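From pyridin-3-yl to pyridin-4-yl: compound 1 and compound 3

A few compounds are considered here, and "the series" means these few. Any claim that something is new, unique, unknown or untested is made for them only; others in the source may bear on it.

Compound 1 `O=C(N/N=C/c1ccc2nonc2c1)c1cccnc1`: 209000 nM
Compound 2 `Cc1nc2ccccn2c1C(=O)N/N=C/c1no[n+]([O-])c1C`: > 400000 nM

Within the data shown here, in an ADME assay on J774.1 cells (Mus musculus) for cytotoxicity, read by MTT assay, with a stated time of 48 h (on this read-out lower numbers stand for stronger inhibition and higher numbers for weaker inhibition), compound 1 gives 209000 nM, the only actual number so far. Compound 2 reads > 400000 nM, which is a limit of the assay and not a number.

Compound 3 `O=C(N/N=C/c1ccc2nonc2c1)c1ccncc1` awaits measurement. It differs from compound 1 by one change: pyridin-4-yl in place of pyridin-3-yl on a carbonyl carbon. The two have the same atoms, joined differently. Among the measured compounds shown here, no measured step shows what this change does, so no step beyond the usual scatter is expected in this assay, in either direction. The expected change is a 1.0-fold higher number from compound 1 to compound 3 (0.00 log units; within the scatter). For compound 3 the estimated value is 210000 nM, with an expected range from 100000 nM to 400000 nM.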

Compound 3, half-maximal inhibitory concentration: > 400000 nM
Compound 3: no number, only a limit; the forecaster's own chance of this, stated with the estimate: 15%; middle value at least 1.9-fold (0.27 log units) from the limit.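

In this assay, among these compounds, moving from pyridin-3-yl to pyridin-4-yl on a carbonyl carbon gives the first step at this position: an at least 1.9-fold higher number from compound 1 to compound 3 (0.28 log units; that floor lies within the scatter). The reading for compound 3 is a limit and not a number. As far as these compounds go, the true size of the step therefore stays unknown, because compound 3 sits at this limit: the limit of > 400000 nM in this assay, at which 2 of the 3 values shown sit.

From the compounds shown here alone, whether the two pyridine isomers truly differ remains open. So does what pyridin-2-yl or a plain phenyl ring would read on the same carbonyl carbon.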